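The compounds below may be only part of what the source reports. "The series", "measured", "known", "first", "only" and "open" are said of these compounds alone.

Compound 1 `Cc1nnc(SCc2cc(=O)c3ccccc3o2)s1`: > 25000 nM
Compound 2 `Nc1nnc(SCc2cc(=O)c3cc(Cl)ccc3o2)s1`: > 25000 nM
Compound 3 `Cc1ccc2oc(CSc3nnc(N)s3)cc(=O)c2c1`: > 25000 nM

In a functional assay on LM7 cells (Homo sapiens) for cytotoxicity, read by MTT assay, with a stated time of 72 h (on this read-out lower numbers stand for stronger inhibition and higher numbers for weaker inhibition), compound 2 gives > 25000 nM, which is a limit of the assay and not a number. Compound 1 gives > 25000 nM, likewise a limit. Compound 3 gives > 25000 nM, again a limit. The whole measured set is summed up by the limit of > 25000 nM in this assay, at which 3 of the 3 values shown sit. Within the data shown here, the one step measured within it, a step that the two limits leave unreadable from compound 2 to compound 3, is therefore of unknown size.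

Compound 4 `Cc1nnc(SCc2cc(=O)c3cc(Cl)ccc3o2)s1` differs from compound 2 by methyl in place of amino on an aromatic carbon; cut one bond further out, this reads 5-amino-1,3,4-thiadiazol-2-yl to 5-methyl-1,3,4-thiadiazol-2-yl. Among the measured compounds shown here, no measured step bears on this exchange directly. Compound 1 already carries the 5-methyl-1,3,4-thiadiazol-2-yl group, and the values of compound 1 and compound 2 both sit at the limit, so they show no difference between them. Compound 4 is thus expected to sit at the limit as well, the estimated step being a step that the limit leaves unreadable from compound 2 to compound 4. For compound 4 the estimated value in this assay is 40000 nM, with a range from 15000 nM to 150000 nM.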

Compound 4, half-maximal inhibitory concentration: > 25000 nM
Compound 4: no number, only a limit; the forecaster's own chance of this, stated with the estimate: 85%; the middle value is on the limit's open side.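

Compound 4 gives > 25000 nM in this assay, which is a limit and not a number. No new step can be read from compound 2 or compound 1 to compound 4, because the set offers only this: the limit of > 25000 nM in this assay, at which 4 of the 4 values shown sit.

The compounds shown leave open how large the exchanges of amino for methyl and of hydrogen for chloro are on the shared core.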